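A few compounds are considered here, and "the series" means these few. Any claim that something is new, unique, unknown or untested is made for them only; others in the source may bear on it.

Measured so far:
Compound 1, `Fc1ccc(F)c(/N=N/Nc2cccc(C(F)(F)F)c2)c1`, gives 80000 nM in an ADME assay on Vero cells (Chlorocebus sabaeus) for cytotoxicity, read by crystal violet staining; a higher number here means that more compound is tolerated, a lower number that less compound is tolerated.
Compound 2, `CN(C)CCCN(/N=N/c1ccccc1)c1cccc(C(F)(F)F)c1`, gives 20000 nM in this assay.
Compound 3, `CN(C)CCCN(/N=N/c1cc(F)ccc1F)c1cccc(C(F)(F)F)c1`, gives 30000 nM in this assay.

Compound 2 and compound 3 share the same change toward their partners: compound 3 differs from compound 2 only by phenyl in place of 2,5-difluorophenyl on a double-bonded nitrogen, and the values of the two lie within the usual scatter, as a 1.5-fold higher number from compound 2 to compound 3 (0.18 log units; within the scatter) shows. From compound 3 to compound 1 the change is hydrogen in place of 3-(dimethylamino)propyl on a nitrogen on an aromatic ring, and it brought a 2.7-fold higher number from compound 3 to compound 1 (0.43 log units; beyond the scatter). The still unmeasured compound 4, `FC(F)(F)c1cccc(N/N=N/c2ccccc2)c1`, is made from compound 2 by the same change, (hydrogen in place of 3-(dimethylamino)propyl on a nitrogen on an aromatic ring), and the surroundings of the changed nitrogen are the same in both pairs, so this is the same change on a core that differs only in the way just described.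

Among the measured compounds shown here, for compound 4 a step in this assay of about a 2.7-fold higher number from compound 2 to compound 4 (0.43 log units; beyond the scatter) is therefore expected, resting on the one earlier instance of this change, because a 2.7-fold higher number from compound 3 to compound 1 (0.43 log units; beyond the scatter) was observed. Compound 4 is estimated at 54000 nM, most likely between 25000 nM and 110000 nM.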

Compound 4, half-maximal cytotoxic concentration: 15000 nM
For compound 4 the middle estimate is 3.6-fold (0.56 log units) above the measured one; the measured number lies below the stated range.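

In this assay, putting hydrogen in place of 3-(dimethylamino)propyl on the core of compound 2 gave a 1.3-fold lower number from compound 2 to compound 4 (0.12 log units; within the scatter) and so left the number within the usual scatter. The two cores differ only by phenyl or 2,5-difluorophenyl on a double-bonded nitrogen, yet the change did not carry over as a step of fixed size: the same change on two cores in this assay, a 2.7-fold higher number (0.43 log units; beyond the scatter) from compound 3 to compound 1 and a 1.3-fold lower number (0.12 log units; within the scatter) from compound 2 to compound 4, 3.6-fold (0.55 log units) apart, beyond the scatter of two such steps. This shows that, in these two pairs, the size of the step depends on the core, but two pairs do not show why it does or predict the step on a third core.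

The compounds shown carry only hydrogen or 3-(dimethylamino)propyl on the nitrogen on an aromatic ring, and only phenyl or 2,5-difluorophenyl on the double-bonded nitrogen. As far as these compounds go, it remains open how a shorter amine chain, a chain ending in a carboxylic acid, or a phenyl bearing a single fluorine would behave in this assay.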